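The compounds below may be only part of what the source reports. "The series", "measured", "known", "first", "only" and "open" are said of these compounds alone.

For the measured compounds named here, in a functional assay on HepG2 cells (Homo sapiens) for inhibition, read by MTT assay, with a stated time of 72 h (a higher number here means a weaker inhibitor, a lower number a stronger inhibitor), compound 1 `Cc1cccc(-n2cc(COc3cccc(NC(=O)Nc4ccc(Cl)c(C(F)(F)F)c4)c3)nn2)c1` gives 7270 nM, and compound 2 `CCc1ccc(-n2cc(COc3cccc(NC(=O)Nc4ccc(Cl)c(C(F)(F)F)c4)c3)nn2)cc1` gives 1950 nM, the lower of the two numbers; the step of a 3.7-fold lower number from compound 1 to compound 2 (0.57 log units; beyond the scatter) is the single measured step. Compound 3 `O=C(Nc1cccc(OCc2cn(-c3ccccc3C(F)(F)F)nn2)c1)Nc1ccc(Cl)c(C(F)(F)F)c1` differs from compound 2 by 2-(trifluoromethyl)phenyl in place of 4-ethylphenyl on an aromatic nitrogen. Going by the values given here, no measured step bears directly on this change; the one step from compound 1 to compound 2 is modest, so a modest step in this assay is expected here too, with no firm direction. The estimate for compound 3 is 3000 nM (range 1000 nM to 9000 nM), an expected step of a 1.5-fold higher number from compound 2 to compound 3 (0.19 log units; within the scatter).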

Compound 3, half-maximal inhibitory concentration: 2320 nM
Compound 3: middle estimate off by 1.3-fold (0.11 log units), on the high side; measured number inside the range.
By their numbers in this assay, from the lowest: compounds 2 and 3 (each within the scatter of the next); then compound 1.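

In this assay, 2-(trifluoromethyl)phenyl in place of 4-ethylphenyl on the aromatic nitrogen gives a 1.2-fold higher number from compound 2 to compound 3 (0.08 log units; within the scatter), so a larger group with fluorine on the ring, in a different ring position, is tolerated here. In place of 3-methylphenyl, the same group gives a 3.1-fold lower number from compound 1 to compound 3 (0.50 log units; beyond the scatter), leaving compound 1 alone at the higher number. No measurement shown accounts for these numbers.

On these data alone, whether an amine or a carboxylic acid on this phenyl ring keeps the number near those of compound 2 and compound 3 remains open. The effects of substituent identity and ring position also remain unseparated, since these compounds change both together.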